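The compounds below may be only part of what the source reports. "The series", "measured", "known", "first", "only" and "open" are said of these compounds alone.

Measured so far in a functional assay on NCI-H322M cells (Homo sapiens) for inhibition, read by sulforhodamine B assay, with a stated time of 48 h; on this read-out lower numbers stand for stronger inhibition of growth and higher numbers for weaker inhibition of growth:
compound 1, `COc1cc(-c2nn(-c3cccc(NC(=O)Nc4cccc(C(F)(F)F)c4)c3)cc2-c2ccncc2)ccc1Cl`, gives 1210 nM;
compound 2, `COc1cc(-c2nn(-c3cccc(NC(=O)Nc4ccc(Cl)c(C(F)(F)F)c4)c3)cc2-c2ccncc2)ccc1Cl`, gives 1500 nM;
compound 3, `COc1cc(-c2nn(-c3cccc(NC(=O)c4ccccc4)c3)cc2-c2ccncc2)ccc1Cl`, gives 4590 nM.

Compound 2 stands second highest of the three; its number sits within the scatter of compound 1 (a 1.2-fold higher number from compound 1 to compound 2 (0.09 log units; within the scatter)) and below compound 3 (a 3.1-fold higher number from compound 2 to compound 3 (0.49 log units; beyond the scatter)). Compound 4, `O=C(Nc1cccc(-n2cc(-c3ccncc3)c(-c3ccc(Cl)c(O)c3)n2)c1)Nc1ccc(Cl)c(C(F)(F)F)c1`, differs from compound 2 in one place: hydrogen in place of methyl on an oxygen on an aromatic ring. For the measured compounds named here, no measured step touches this oxygen; the two known steps concern the urea and amide end only, so they give no direct guide. The change is small in atom count, so the expected step in this assay is a 1.2-fold higher number from compound 2 to compound 4 (0.08 log units; within the scatter), no change beyond the scatter. Compound 4 is therefore estimated at 1800 nM, with a range from 700 nM to 4500 nM.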

Compound 4, concentration for 50% growth inhibition: 1090 nM
For compound 4 the middle estimate is 1.7-fold (0.22 log units) above the measured one; the measured number falls inside the stated range.
By their numbers in this assay, from the lowest: compounds 4, 1 and 2 (each within the scatter of the next); then compound 3.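

Going from methoxy to hydroxy on the aromatic ring gives a 1.4-fold lower number from compound 2 to compound 4 (0.14 log units; within the scatter) in this assay, so with this urea, the oxygen can carry either a methyl or a hydrogen without a change beyond the scatter. For the compounds shown here, this is the first look at this position, as the earlier steps touched only the urea and amide end. The compounds shown leave open what an ethyl or a longer chain on this oxygen would do, or an amine in its place. No evidence is at hand on what lies behind this result.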